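Swapping the N-aryl group in a diphenylglutarimide series

The source may report more compounds than this note shows. Statements on the series, on what has been measured and on what is new or still open speak of the compounds shown alone.

Measured compounds: compound 1 `O=C1C(c2ccccc2)CC(c2ccccc2)C(=O)N1c1ccccc1` with 43.7 mg/kg in a functional assay on the whole organism (strain Swiss albino) with Mus musculus as the target, in the maximal electroshock model, with a stated time of 2 h; a lower number here means that less compound is needed, a higher number that more compound is needed for the effect; compound 2 `O=C1C(c2ccccc2)CC(c2ccccc2)C(=O)N1c1cccc(Cl)c1` with > 100 mg/kg in this assay.

Compound 2 sits at a limit of this assay, (the limit of > 100 mg/kg in this assay, at which 1 of the 2 values shown sits), so only a range is known for it. The step of an at least 2.2-fold higher number from compound 1 to compound 2 (0.35 log units; beyond the scatter) is the sole measured one, and it runs away from the phenyl parent.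

Compound 3 `Cc1ccc(N2C(=O)C(c3ccccc3)CC(c3ccccc3)C2=O)cc1` is not yet measured. Its change from compound 2 is 4-methylphenyl in place of 3-chlorophenyl on an amide-type nitrogen in a ring. Among the measured compounds shown here, no measured step covers a methyl on this ring, so the chloro step is the only guide, and it shows that a substituent on the N-aryl ring can push the dose upward. Compound 3 is therefore expected to lie near or somewhat under the parent side of that step, but with wide uncertainty. The expected step is an at least 1.4-fold lower number from compound 2 to compound 3 (0.15 log units; that floor lies within the scatter). Compound 3 is estimated at 70 mg/kg, between 30 mg/kg and 160 mg/kg.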

Compound 3, dose for half-maximal effect: 82 mg/kg
For compound 3 the middle estimate is 1.2-fold (0.07 log units) below the measured one, within the range that was stated.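

Methyl in place of hydrogen on the aromatic ring gives a 1.9-fold higher number from compound 1 to compound 3 (0.27 log units; within the scatter), so a substituent on the ring carried by the amide-type nitrogen need not shift the dose beyond the scatter, as the chloro step did. The exchange of 3-chlorophenyl for 4-methylphenyl gives an at least 1.2-fold lower number from compound 2 to compound 3 (0.08 log units; that floor lies within the scatter), a direction that stays unsettled with its floor inside the scatter. Compound 2 gives only a limit, not a number: the limit of > 100 mg/kg in this assay, at which 1 of the 3 values shown sits.

The group and its place on the ring remain unseparated, with chloro and methyl standing at different ring positions in compound 2 and compound 3. From the compounds shown here alone, how a methoxy group or an amine on this ring would read in this assay also stays open.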